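A few compounds are considered here, and "the series" means these few. Any claim that something is new, unique, unknown or untested is made for them only; others in the source may bear on it.

Compound 1 `Cn1cc(-c2ccc(=O)n(CCOc3ccnc4cc(OCCCCCC(=O)NO)ccc34)n2)cn1` and compound 2 `Cn1cc(-c2ccc(=O)n(CCOc3ccnc4cc(OCCCCCS)ccc34)n2)cn1` have both been tested in a functional assay on HCT-116 cells (Homo sapiens) for antiproliferative activity, read by sulforhodamine B assay, with a stated time of 72 h; a higher number here means a weaker inhibitor, a lower number a stronger inhibitor. Compound 1 gives > 10000 nM, which is a limit of the assay and not a number. Compound 2 gives > 10000 nM, which is likewise only a limit. Among the measured compounds shown here, the one measured change is a step that the two limits leave unreadable from compound 1 to compound 2, and the evidence amounts to the limit of > 10000 nM in this assay, at which 2 of the 2 values shown sit. Compound 3 `CC(=O)CCCCCOc1ccc2c(OCCn3nc(-c4cnn(C)c4)ccc3=O)ccnc2c1` differs from compound 2 as follows: acetyl in place of sulfanyl on a saturated chain carbon, five bonds along the chain from an oxygen on an aromatic ring. In short, it carries acetyl in place of sulfanyl on a saturated chain carbon, five bonds along the chain from an oxygen on an aromatic ring. For the measured compounds named here, no measured step of readable size bears on this change, so no shift beyond the scatter is expected in this assay, and no direction can be given. The expected step is a step that the limit leaves unreadable from compound 2 to compound 3. Compound 3 is estimated at 15000 nM, with an expected range from 6000 nM to 40000 nM.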

Compound 3, half-maximal inhibitory concentration: > 10000 nM
Compound 3 gave a limit, no number; the forecaster's own chance of this, stated with the estimate: 85%; the middle value is on the limit's open side.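

In this assay compound 3 gives > 10000 nM as a limit and not a number, so no step from compound 1 or compound 2 to compound 3 can be read: the limit of > 10000 nM in this assay, at which 3 of the 3 values shown sit.

The compounds shown leave open whether hydroxycarbamoyl, sulfanyl and acetyl at this chain end differ at all in this assay when measured as numbers.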